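Swapping Ethyl for Cyclopentyl on a Lipoxygenase Inhibitor Chain

A few compounds are considered here, and "the series" means these few. Any claim that something is new, unique, unknown or untested is made for them only; others in the source may bear on it.

Three fatty-acid-like compounds were examined in an assay on RBL-1 cells for inhibition of Polyunsaturated fatty acid 5-lipoxygenase (Rattus norvegicus); a higher number here means a weaker inhibitor, a lower number a stronger inhibitor. Compound 1 `CCCCC[C@@H](/C=C/C=C\C/C=C\C/C=C\CCCC(=O)O)OC(C)=O` gives 17000 nM in this assay. Compound 2 `O=C(O)CCCCCCCCC/C=C/C=C/C(O)CC1CCCC1` gives 61000 nM. Compound 3 `CCCC(O)/C=C/C#CCCCCCCCCCC(=O)O` gives 260000 nM, the highest of the three numbers; the gap to compound 2 and the larger gap to compound 1 both lie beyond the usual scatter, so compound 3 is the weakest inhibitor of the set.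

The step under consideration leads from compound 3 to compound 4 `O=C(O)CCCCCCCCCC#C/C=C/C(O)CC1CCCC1`, which has not yet been measured in this assay. The change is cyclopentyl in place of ethyl on a saturated chain carbon, two bonds along the chain from a double-bonded chain carbon and an oxygen on a saturated carbon. Among the compounds with values here, no step between two measured compounds covers this exchange on its own, so its size must be inferred. Compound 2, which also carries the cyclopentyl group on a saturated chain carbon bearing an oxygen, sits well below compound 3, but its chain also differs elsewhere, so only the two values themselves can be compared.

On that basis the number for compound 4 is expected to fall, by a step of a 2.9-fold lower number from compound 3 to compound 4 (0.46 log units; beyond the scatter), toward the region occupied by compound 2. The estimate for compound 4 in this assay is 90000 nM, with a plausible range from 30000 nM to 270000 nM.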

Compound 4, half-maximal inhibitory concentration: 82000 nM
Estimate against measurement, compound 4: 1.1-fold (0.04 log units) above; the range from low to high includes it.
By their numbers in this assay, from the lowest: compound 1; then compounds 2 and 4 (each within the scatter of the next); then compound 3.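

In this assay, within the data shown here, the exchange of ethyl for cyclopentyl on this saturated chain carbon now has a size of its own, a modest step of a 3.2-fold lower number from compound 3 to compound 4 (0.50 log units; beyond the scatter), toward stronger inhibition, and the earlier compounds, which differ from one another in more than one place, could not give this reading. The position therefore accepts the five-membered carbon ring without any loss of inhibition, and with that ring in place, compound 4 at 82000 nM and compound 2 at 61000 nM lie within the scatter of each other, so the triple bond of compound 4 and the double bond at the same place in compound 2 cannot be told apart here. Nothing available gives a reason for the step from ethyl to cyclopentyl, and it remains an observation from a single pair. As far as these compounds go, whether a cyclohexyl or phenyl group on the same carbon would move the number further, or whether an open-chain butyl group would do as much as the ring, remains open. So does whether the same exchange would give a step of similar size on the chain of compound 1, which stays the strongest inhibitor shown.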